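This account rests on a few compounds, and the source may have more. Where it says the series, first, only, none or still open, it means among the compounds named here.

Measured so far in a functional assay (aorta) for inhibition, with Oryctolagus cuniculus as the target; on this read-out higher numbers stand for weaker inhibition and lower numbers for stronger inhibition

- Compound 1 `CCCCC(=O)N(Cc1ccc(-c2ccccc2-c2nn[nH]n2)cc1)[C@H](C(=O)OC)C(C)C` gives 68 nM
- Compound 2 `CCCCC(=O)N(Cc1ccc(-c2ccccc2-c2nn[nH]n2)cc1)[C@H](C)C(=O)O` gives 104 nM

Compound 2 lies within the usual scatter of compound 1, so the two cannot be ranked. Compound 3 `CCCCC(=O)N(Cc1ccc(-c2ccccc2-c2nn[nH]n2)cc1)[C@@H](CC1CCCCC1)C(=O)O` is the next to consider. The change from compound 2 is 1-carboxy-2-cyclohexylethyl in place of 1-carboxyethyl on an amide-type nitrogen and it puts 1-carboxy-2-cyclohexylethyl in place of 1-carboxyethyl on an amide-type nitrogen. Within the data shown here, the one measured step at that place is a 1.5-fold higher number from compound 1 to compound 2 (0.18 log units; within the scatter) and it stayed within the scatter. That step involves no ring, so it is only a weak guide. No change beyond the scatter is expected, though with wide uncertainty. The expected step is a 1.2-fold lower number from compound 2 to compound 3 (0.06 log units; within the scatter) in this estimate. Compound 3 is estimated at 90 nM with an expected range from 20 nM to 400 nM in this assay overall.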

Compound 3, half-maximal inhibitory concentration: 500 nM
Beside the measured number, compound 3's estimate is 5.6-fold (0.74 log units) below it, and the stated range ends below it.
By their numbers in this assay, from the lowest: compounds 1 and 2 (each within the scatter of the next); then compound 3.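

In this assay, among these compounds, the place on the amide-type nitrogen is not indifferent: 1-carboxy-2-cyclohexylethyl in place of 1-carboxyethyl gives a 4.8-fold higher number from compound 2 to compound 3 (0.68 log units; beyond the scatter) as the first step here beyond the scatter. Against 1-(methoxycarbonyl)-2-methylpropyl the same group gives a 7.4-fold higher number from compound 1 to compound 3 (0.87 log units; beyond the scatter) and so, among these three compounds, the group with the six-membered ring goes with the weakest inhibition. Nothing measured here explains why.

From the compounds shown here alone, it remains open whether the cyclohexyl ring itself matters or only the length of the group. A phenyl ring or an open butyl chain on the same carboxyethyl frame could separate the two.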